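The compounds below may be only part of what the source reports. "The series", "measured", "known", "first", "only" and "open" are said of these compounds alone.

Compound 1 `O=C(NNc1ccccc1Cl)c1ccc(NS(=O)(=O)c2cnc(O)nc2O)cc1`: 4010 nM
Compound 2 `O=C(NNc1ccccc1F)c1ccccc1NS(=O)(=O)c1cnc(O)nc1O`: > 20000 nM (a limit, not a number)

Among the measured compounds shown here, in a functional assay on MDA-MB-231 cells (Homo sapiens) for antiproliferative activity, read by MTT assay, with a stated time of 24 h (a lower number here means a stronger inhibitor, a higher number a weaker inhibitor), compound 1 gives 4010 nM as the only exact number so far. The reading of > 20000 nM for compound 2 is a limit of the test.

Compound 3 `Cc1ccc(C(=O)NNC(=O)c2ccc(NS(=O)(=O)c3cnc(O)nc3O)cc2)cc1` has (4-methylphenyl)carbonyl in place of 2-chlorophenyl on an amine nitrogen, and (4-methylphenyl)carbonyl in place of 2-chlorophenyl on an amine nitrogen gives the full count of that change. For the measured compounds named here, no measured pair shows what this swap does, so no step beyond the usual scatter is expected in this assay and neither direction is favoured. Compound 3 is expected at 6000 nM with 1800 nM and 20000 nM as the ends of the estimated range. That estimate means a 1.5-fold higher number from compound 1 to compound 3 (0.18 log units; within the scatter) as the expected change.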

Compound 3, half-maximal inhibitory concentration: > 20000 nM
Compound 3: a limit, no number (the forecaster's own chance of this, stated with the estimate: 15%); at least 3.3-fold (0.52 log units) between middle value and limit.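

In this assay putting (4-methylphenyl)carbonyl in place of 2-chlorophenyl, on an amine nitrogen whose other neighbour is an amide-type nitrogen, gives an at least 4.9-fold higher number from compound 1 to compound 3 (0.69 log units; beyond the scatter) and so shows that this position responds to a change of group. The reading for compound 3 is a limit, not a number, so the direction of the step is known but its full size is not: the limit of > 20000 nM in this assay, at which 2 of the 3 values shown sit.

This single swap brings in the carbonyl and the methyl group together, so their separate effects cannot be told apart. On these data alone, how a simple amine or a carboxylic acid would read at this nitrogen remains open.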